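The source may hold more compounds than are shown below. What is called first, only, known or untested is meant among the compounds shown, and "the series" means these compounds.

Measured compounds:
Compound 1 `CNC(=O)c1cc(Oc2ccc3nc(NC(=O)c4ccc(Cl)cc4)sc3c2)ccn1`, which in a functional assay on SK-BR-3 cells (Homo sapiens) for inhibition, read by MTT assay, with a stated time of 2 days, tested at 10 uM (on this read-out lower numbers stand for less inhibition of growth and higher numbers for more inhibition of growth at the one concentration tested), gives 18.9%.
Compound 2 `CNC(=O)c1cc(Oc2ccc3nc(NC(=O)c4cc(Cl)cc(Cl)c4)sc3c2)ccn1`, which in this assay gives 9.62%.

Compound 2 holds the lower of the two numbers, but the step of a number 9.3 percentage points lower from compound 1 to compound 2 (within the scatter) is within the scatter, so the two compounds cannot be told apart on this read-out. Compound 3 `CNC(=O)c1cc(Oc2ccc3nc(NC(=O)c4cccc(F)n4)sc3c2)ccn1` has not been measured. It differs from compound 2 in one place: 6-fluoropyridin-2-yl in place of 3,5-dichlorophenyl on a carbonyl carbon. Among the measured compounds shown here, only one measured step touches the same carbonyl carbon, the step from compound 1 to compound 2, and it did not move the number beyond the scatter. On that basis no step beyond the scatter is expected in this assay from compound 2 to compound 3; the estimated step is a number 3.4 percentage points higher from compound 2 to compound 3 (within the scatter). Compound 3 is therefore expected to give about 13%, in a range from 0% to 32%.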

Compound 3, percent growth inhibition at one concentration: 12.5%
Estimate against measurement, compound 3: 0.5 percentage points above, within the range that was stated.
By their numbers in this assay, from the lowest: compounds 2, 3 and 1 (each within the scatter of the next).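

In this assay, the change at this carbonyl carbon now includes a ring with a hetero atom in place of a ring of carbon only, and a number 2.9 percentage points higher from compound 2 to compound 3 (within the scatter) and a number 6.4 percentage points lower from compound 1 to compound 3 (within the scatter) both lie within the scatter. The three groups on this carbonyl carbon, 4-chlorophenyl, 3,5-dichlorophenyl and 6-fluoropyridin-2-yl, therefore cannot be told apart on this read-out, even though 6-fluoropyridin-2-yl carries a hydrogen-bond acceptor and no chlorine. No measurement is available to explain why these groups read alike.

The compounds shown leave open whether any group on this carbonyl carbon can move the number beyond the scatter. A saturated amine such as piperidine or a carboxylic acid in place of the aromatic ring would be a different kind of change at this position.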